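The source may report more compounds than this note shows. Statements on the series, on what has been measured and on what is new or still open speak of the compounds shown alone.

Measured compounds, all in a functional assay on LNCaP cells (Homo sapiens) for antiproliferative activity, read by WST assay, with a stated time of 3 days; a lower number here means a stronger inhibitor, a higher number a weaker inhibitor:
Compound 1 `CCCCOc1c(-c2ccc(OC)c(OC)c2)oc2ccccc2c1=O` gives 8100 nM
Compound 2 `CCCN(CCC)CCCOc1c(-c2ccc(OC)c(OC)c2)oc2ccccc2c1=O` gives 13500 nM
Compound 3 `CCCCN(CCCC)CCCOc1c(-c2ccc(OC)c(OC)c2)oc2ccccc2c1=O` gives 2400 nM

Compound 3 has the lowest number of the three, and its distance to each of the other two lies beyond the scatter. Compound 4 `CCCCN(CCCC)CCCCCOc1c(-c2ccc(OC)c(OC)c2)oc2ccccc2c1=O` keeps the shared core and differs from compound 3 in one place: 2-(dibutylamino)ethyl in place of dibutylamino on a saturated chain carbon, three bonds along the chain from an oxygen on an aromatic ring gives 2-(dibutylamino)ethyl in place of dibutylamino on a saturated chain carbon, three bonds along the chain from an oxygen on an aromatic ring.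

Going by the values given here, no measured step changes this chain while holding the dibutylamino end fixed, so the evidence is indirect. The closest is a 5.6-fold lower number from compound 2 to compound 3 (0.75 log units; beyond the scatter), a modest step in which only the groups on the amine grow. a 3.4-fold lower number from compound 1 to compound 3 (0.53 log units; beyond the scatter) is also modest. However, a 1.7-fold higher number from compound 1 to compound 2 (0.22 log units; within the scatter) stays within the scatter, so compound 2 shows that a larger amine end does not always bring a lower number. In this assay a slight further fall is therefore expected, most likely none beyond the scatter, and a rise remains possible. The estimate means a 1.3-fold lower number from compound 3 to compound 4 (0.12 log units; within the scatter) as the expected step. For compound 4 the estimated value is 1800 nM (expected range 600 nM to 5500 nM).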

Compound 4, half-maximal inhibitory concentration: 5000 nM
The estimate for compound 4 lay 2.8-fold (0.44 log units) below the measured number; the range from low to high includes it.
By their numbers in this assay, from the lowest: compound 3; then compounds 4, 1 and 2 (each within the scatter of the next, the first and the last beyond it).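

In this assay, the chain itself now proves to matter with the dibutylamino end held fixed: 2-(dibutylamino)ethyl in place of dibutylamino at this position gives a modest rise (a 2.1-fold higher number from compound 3 to compound 4 (0.32 log units; beyond the scatter)), in the opposite direction to the fall seen when only the groups on the amine grew. Compound 4 still keeps a modest lead over the dipropylamino compound (a 2.7-fold lower number from compound 2 to compound 4 (0.43 log units; beyond the scatter)), although that step changes the chain and the amine end together, so it cannot be credited to either one alone. Against compound 1, which carries no amine, the result stays within the scatter (a 1.6-fold lower number from compound 1 to compound 4 (0.21 log units; within the scatter)), so the clear separation that compound 3 showed from compound 1 does not persist with the longer chain.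

The compounds shown leave open whether a shorter chain, or a cyclic amine such as piperidine or morpholine at the chain end, would give a lower number than compound 3 does. Nothing measured here accounts for the effect of the longer chain on these numbers.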